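The source may report more compounds than this note shows. Statements on the series, on what has been measured and on what is new or still open speak of the compounds shown alone.

In an ADME assay on microsomes from liver (Mus musculus) for metabolic stability, read by LC-MS, using NADPH, with stated times of 10 min and 30 min, tested at 1 uM (a lower number here means slower removal, a higher number faster removal of the compound), compound 1 `COC(=O)C1=C(C)NC(c2nccs2)=NC1(C)c1ccc(F)c(F)c1` gives 83 mL/min/kg and compound 2 `COC(=O)C1=C(CN2CCC(O)CC2)NC(c2nccs2)=NC1(C)c1ccc(F)cc1` gives 81 mL/min/kg so the two stand within the usual scatter of each other. Compound 3 `COC(=O)C1=C(CN2CC(OC)C2)NC(c2nccs2)=NC1(C)c1ccc(F)cc1` carries 3-methoxyazetidin-1-yl in place of 4-hydroxypiperidin-1-yl on a saturated chain carbon bound to a double-bonded ring carbon, the difference being 3-methoxyazetidin-1-yl in place of 4-hydroxypiperidin-1-yl on a saturated chain carbon bound to a double-bonded ring carbon and the rest of compound 2 unchanged. Within the data shown here, no step between measured compounds offers a guide, so no change beyond the scatter is expected in this assay and the estimated 1.2-fold lower number from compound 2 to compound 3 (0.10 log units; within the scatter) leans only slightly towards slower removal. For compound 3 the expected clearance is 65 mL/min/kg with an estimated range of 35 mL/min/kg to 105 mL/min/kg before any measurement.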

Compound 3, clearance: 88 mL/min/kg
Estimate against measurement, compound 3: 1.4-fold (0.13 log units) below; the measured number falls inside the stated range.
By their numbers in this assay, from the lowest: compounds 2, 1 and 3 (each within the scatter of the next).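

In this assay, 3-methoxyazetidin-1-yl in place of 4-hydroxypiperidin-1-yl on a saturated chain carbon bound to a double-bonded ring carbon gives a 1.1-fold higher number from compound 2 to compound 3 (0.04 log units; within the scatter). At this position, then, a four-membered ring with no hydrogen-bond donor and a six-membered ring with one cannot be told apart by clearance. Nothing available accounts for this result.

Compound 1 differs from compound 2 in more than one place, so the contribution of the amine alone cannot be read. As far as these compounds go, whether a carboxylic acid or a morpholin-4-yl group on this carbon would shift clearance beyond the scatter stays open.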